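Diastereomer of compound 3 in the PANC-1 cytotoxicity series

This account rests on a few compounds, and the source may have more. Where it says the series, first, only, none or still open, it means among the compounds named here.

Measured so far:
compound 1 `C=C1C(=O)O[C@@H](c2ccccc2)[C@H]1C`: 143%
compound 2 `C=C1C(=O)O[C@H](c2ccc3ccccc3c2)[C@H]1C`: 139%
compound 3 `C=C1C(=O)O[C@@H](c2ccccc2)[C@H]1c1ccccc1`: 108%

In a functional assay on PANC-1 cells (Homo sapiens) for cytotoxicity, read by MTT assay, with a stated time of 72 h, tested at 1 uM (on this read-out lower numbers stand for a stronger effect and higher numbers for a weaker effect at the one concentration tested), compound 3 gives 108%, the lowest of the three numbers, with both other compounds above it beyond the scatter. Among the compounds with values here, the one step that was measured, a number 35 percentage points lower from compound 1 to compound 3 (beyond the scatter), concerns a group exchange and not configuration.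

Compound 4 `C=C1C(=O)O[C@H](c2ccccc2)[C@H]1c1ccccc1` is not yet measured. It differs from compound 3 as follows: the two compounds have the same atoms and bonds and differ only in configuration as drawn: 1 of 2 stereo elements differ; a stereocentre at a saturated ring carbon is drawn R in compound 3 and S in compound 4. Within the data shown here, no measured step bears on a change of configuration alone, so there is no basis for expecting a step beyond the scatter in this assay in either direction; the uncertainty is therefore wide.

Compound 4 is estimated at 110%, within 85% to 140%, which corresponds to an expected step of a number 2 percentage points higher from compound 3 to compound 4 (within the scatter).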

Compound 4, a percentage reported as activity, at one concentration (the size of the read-out at that concentration, not a potency): 116%
Estimate against measurement, compound 4: 6 percentage points below; measured number inside the range.
By their numbers in this assay, from the lowest: compounds 3 and 4 (each within the scatter of the next); then compounds 2 and 1 (each within the scatter of the next).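

In this assay, within the data shown here, the change of configuration at this saturated ring carbon gives a number 8 percentage points higher from compound 3 to compound 4 (within the scatter) and is the only reading so far on configuration alone. With phenyl on this carbon, the drawn configuration therefore does not separate the two compounds beyond the scatter. The pair isolates this single change: the fact that compounds 3 and 4 differ only in the configuration as drawn.

Still open, on these data alone, is whether a change of configuration at this carbon reads the same with the methyl of compound 1 in place of phenyl. Also open, as far as these compounds go, is how an amine or a carboxylic acid at this carbon would read.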